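A few compounds are considered here, and "the series" means these few. Any claim that something is new, unique, unknown or untested is made for them only; others in the source may bear on it.

Measured in a functional assay on A2780 cells (Homo sapiens) for antiproliferative activity, read by CellTiter-Glo, with a stated time of 4 days (a lower number here means a stronger inhibitor, a higher number a weaker inhibitor), so far
- compound 1 `CC(=O)NCc1ncc2cc(COc3ccc(C(=O)NCc4cccnc4)cc3)n(CCC3CCCCC3)c2n1` gives 15 nM
- compound 2 `CCC(=O)NCc1ccc(NC(=O)[C@H]2C[C@@H]2c2cccnc2)cc1` gives 405 nM

Compound 2 holds the higher of the two numbers, and its gap to compound 1 lies beyond the scatter. Compound 3 `CCC(=O)N[C@@H](C)c1ccc(NC(=O)[C@H]2C[C@@H]2c2cccnc2)cc1` differs from compound 2 in one place: methyl in place of hydrogen on a saturated chain carbon bound to an amide-type nitrogen and an aromatic carbon. Going by the values given here, no measured pair shows this change, so the expectation is loose: no step beyond the scatter in this assay and no firm direction. The estimated step is a 1.2-fold lower number from compound 2 to compound 3 (0.06 log units; within the scatter) and remains uncertain. The expected value for compound 3 is 350 nM, with a range of 90 nM to 1300 nM as estimated.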

Compound 3, half-maximal inhibitory concentration: 5 nM
Compound 3: the middle estimate sits 70-fold (1.85 log units) above what was measured; measured number below the stated range.
By their numbers in this assay, from the lowest: compound 3; then compound 1; then compound 2.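

In this assay, methyl in place of hydrogen on this saturated chain carbon gives an 81-fold lower number from compound 2 to compound 3 (1.91 log units; beyond the scatter) from a change of a single heavy atom. Going by these compounds alone, the chain carbon bound to an amide-type nitrogen and an aromatic carbon is therefore a highly sensitive position, although only this one pair speaks for it. No evidence on the origin of the step is available here.

From the compounds shown here alone, whether ethyl, hydroxymethyl or a second methyl on this carbon would keep the gain remains open. The compounds shown also leave open how the opposite configuration at this carbon would compare.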